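The source may report more compounds than this note shows. Statements on the series, on what has been measured and on what is new or still open speak of the compounds shown alone.

Measured in a functional assay on the whole organism (Ear) for inhibition, with Mus musculus as the target, with a stated time of 30 min, at a dose of 100 mg/kg by the intraperitoneal route; on this read-out lower numbers stand for less inhibition and higher numbers for more inhibition at the one dose given (going by the name of the read-out):
compound 1, `O=C(/C=C/c1ccc(/C=N/NC(=O)c2ccncc2)cc1)c1cccc(Br)c1`, 14%
compound 2, `N=C(N)N/N=C/c1ccc(/C=C/C(=O)c2cccc(Br)c2)cc1`, 49.7%
compound 3, `O=C(N/N=C/c1ccc(/C=C/C(=O)c2ccccc2Cl)cc1)c1cccc(Cl)c1`, 43%

Compound 2 stands highest of the three numbers. Compound 3 sits nearest, and that gap is within the scatter, so no order between compound 2 and compound 3 is claimed. Compound 1 lies furthest, and the step of a number 35.7 percentage points higher from compound 1 to compound 2 (beyond the scatter) is beyond the scatter. That single measured step exchanges the group on the amine nitrogen and leaves the ketone aryl untouched.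

Compound 4, `N=C(N)N/N=C/c1ccc(/C=C/C(=O)c2ccc(Cl)cc2Cl)cc1`, is not yet measured. It differs from compound 2 in that (2,4-dichlorophenyl in place of 3-bromophenyl on a carbonyl carbon). For the measured compounds named here, no measured pair differs only at the carbonyl carbon: compound 1 and compound 3 differ from each other in two places, so their values show only that a chlorinated aryl on the carbonyl is compatible with the number seen for compound 3. Going by the values given here, with no step bearing on this change, no shift beyond the scatter is expected in this assay in either direction. Compound 4 is therefore estimated at 45% (range 25% to 65%), which means an expected step of a number 4.7 percentage points lower from compound 2 to compound 4 (within the scatter).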

Compound 4, a percentage reported as inhibition, in the whole organism at one dose (the size of the read-out at that dose, not a potency): 92.5%
The estimate for compound 4 lay 47.5 percentage points below the measured number; measured number above the stated range.
By their numbers in this assay, from the lowest: compound 1; then compounds 3 and 2 (each within the scatter of the next); then compound 4.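

In this assay, the aryl on the carbonyl carbon had not been tested by any single-place step; 2,4-dichlorophenyl in place of 3-bromophenyl, with the rest of compound 2 unchanged, gives a number 42.8 percentage points higher from compound 2 to compound 4 (beyond the scatter). The carbonyl carbon is therefore a second place where one exchange moves this read-out beyond the scatter, alongside the group on the amine nitrogen in a number 35.7 percentage points higher from compound 1 to compound 2 (beyond the scatter). Nothing available accounts for the size of the new step.

This single step changes the halogen, the number of halogens and their placement together, so the compounds shown cannot separate these contributions. Also open, going by these compounds, is how an unsubstituted phenyl or a methoxyphenyl on the carbonyl carbon would compare with 2,4-dichlorophenyl, with the group on the amine nitrogen held as in compound 4.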